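The compounds below may be only part of what the source reports. "The series", "measured", "known", "first", "only" and "open" are said of these compounds alone.

Of the compounds shown here, three have been measured in a functional assay on HEK293 cells for agonist activity at G-protein coupled receptor 52 (Homo sapiens), read by cAMP accumulation, with a stated time of 15 min; a lower number here means a smaller maximal response, a higher number a larger maximal response. Compound 1 `O=C(NCCO)c1cccc2c1CCN2c1nccc(Cc2cc(F)cc(C(F)(F)F)c2)n1` gives 138% in this assay. Compound 2 `Cc1c(Cc2cc(F)cc(C(F)(F)F)c2)cnnc1N1CCc2c(C(=O)NCCO)cccc21` gives 119%. Compound 3 `O=C(NCCO)c1cccc2c1CCN2c1cc(Cc2cccc(C(F)(F)F)c2)ncn1` gives 127%. Compound 3 thus stands second highest of the three numbers: its number and that of compound 2 lie within the scatter of each other, while the number of compound 1 lies beyond the scatter above it.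

Compound 4 `O=C(NCCO)c1cccc2c1CCN2c1cc(Cc2cccc(F)c2)ncn1` has not yet been measured. Relative to compound 3 the change is fluoro in place of trifluoromethyl on an aromatic carbon. Among the compounds with values here, no pair of measured compounds differs in one place only, so the numbers so far do not fix how large a step this kind of change brings. All three measured compounds give maximal responses above the reference, and the shared core of compound 3 is untouched, so the expected step in this assay is a number 7 percentage points lower from compound 3 to compound 4 (within the scatter), that is, nothing beyond the scatter, with at most a slight downward lean. Compound 4 is therefore expected to give about 120% in this assay, within the range 100% to 140%.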

Compound 4, largest response reached (Emax), in percent of the reference or control that the assay uses: 148%
Compound 4: the middle estimate sits 28 percentage points below what was measured; the whole stated range lies below it.
By their numbers in this assay, from the lowest: compounds 2 and 3 (each within the scatter of the next); then compounds 1 and 4 (each within the scatter of the next).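

Within the data shown here, this is the first step that can be read at a single place: in this assay, fluoro in place of trifluoromethyl on an aromatic carbon, meta to a large group, gives a number 21 percentage points higher from compound 3 to compound 4 (beyond the scatter). Trifluoromethyl is therefore not required at this place for a maximal response of this size, and one heavy atom in place of four does not lower the read-out here, with compound 4 at 148%. Nothing measured on these compounds speaks to what lies behind this step.

Open, on these data alone, is whether chloro, a nitrile or a methoxy group at this place would give a response like that of fluoro or of trifluoromethyl. Also open, as far as these compounds go, is whether the same change brings a step of like size on the cores of compound 1 and compound 2, since this remains a single pair.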